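Swapping an aryl sulfonyl for a pyrrolidine carbonyl

This account rests on a few compounds, and the source may have more. Where it says the series, first, only, none or still open, it means among the compounds named here.

Compound 1, with the structure `O=C(O)c1cccc(S(=O)(=O)N2CCC(NS(=O)(=O)c3cc(S(=O)(=O)c4ccccc4)ccc3C(F)(F)F)CC2)c1`, shows 12500 nM in a physicochemical assay for solubility; on this read-out higher numbers stand for higher solubility and lower numbers for lower solubility. Compound 2, `CC(C)(C)OC(=O)N1CCC(CC(=O)N2CCC(NS(=O)(=O)c3cc(S(=O)(=O)c4ccccc4)ccc3C(F)(F)F)CC2)CC1`, gives 12500 nM in this assay, so the two sit level within the scatter. Compound 3, `O=C([C@@H]1CCNC1)N1CCC(NS(=O)(=O)c2cc(S(=O)(=O)c3ccccc3)ccc2C(F)(F)F)CC1`, has not yet been measured in this assay. It differs from compound 1 in one place: (pyrrolidin-3-yl)carbonyl in place of (3-carboxyphenyl)sulfonyl on an amine nitrogen in a ring. Among the measured compounds shown here, no measured pair shows this change, so the size of its effect is unknown; a step of a 1.6-fold higher number from compound 1 to compound 3 (0.20 log units; within the scatter) is expected, which stays within the scatter. Compound 3 is therefore estimated at 20000 nM, with a likely range from 6000 nM to 70000 nM.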

Compound 3, solubility: 12500 nM
Beside the measured number, compound 3's estimate is 1.6-fold (0.20 log units) above it; measured number inside the range.
By their numbers in this assay, from the lowest: compounds 1, 2 and 3 (each within the scatter of the next).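

In this assay, the number runs no change at the digits printed from compound 1 to compound 3 (within the scatter) when (pyrrolidin-3-yl)carbonyl takes the place of (3-carboxyphenyl)sulfonyl on the amine nitrogen. At this position, then, a group of 12 heavy atoms with an aromatic ring can give way to one of 7 heavy atoms with a five-membered non-aromatic ring, and the read-out stays within the scatter. Nothing available explains this outcome. Still open, going by these compounds, is what this nitrogen would show with a small acetyl group or a longer alkyl chain.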